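A few compounds are considered here, and "the series" means these few. Any claim that something is new, unique, unknown or untested is made for them only; others in the source may bear on it.

Compound 1 `CC(C)C[C@H](NC(=O)c1cc(Cl)ccc1OCCNC(=O)OC(C)(C)C)C(=O)Nc1ccc([N+](=O)[O-])cc1Cl`: > 10000 nM
Compound 2 `CC[C@@H](C)[C@H](NC(=O)c1cc(Cl)ccc1OCCNC(=O)OC(C)(C)C)C(=O)Nc1ccc([N+](=O)[O-])cc1Cl`: 10500 nM

For the measured compounds named here, in a functional assay on MCF7 cells (Homo sapiens) for inhibition, read by MTT assay, with a stated time of 72 h (a higher number here means a weaker inhibitor, a lower number a stronger inhibitor), compound 2 gives 10500 nM, the only number so far. For compound 1, > 10000 nM is a limit and not a number. Compound 3 `CSCC[C@H](NC(=O)c1cc(Cl)ccc1OCCNC(=O)OC(C)(C)C)C(=O)Nc1ccc([N+](=O)[O-])cc1Cl` differs from compound 2 as follows: 2-(methylsulfanyl)ethyl in place of sec-butyl on a saturated chain carbon bound to an amide-type nitrogen and a carbonyl carbon. Going by the values given here, the one measured step at this place, a step that the limit leaves unreadable from compound 1 to compound 2, has no readable size, so it gives no ground for expecting a change beyond the scatter in this assay, in either direction. The expected step is a 1.1-fold lower number from compound 2 to compound 3 (0.02 log units; within the scatter). For compound 3 the estimated value is 10000 nM, with an expected range of 4000 nM to 20000 nM.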

Compound 3, half-maximal inhibitory concentration: > 10000 nM
Compound 3 gave a limit, no number; the forecaster's own chance of this, stated with the estimate: 45%; the middle value sits exactly at the limit.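

In this assay compound 3 gives > 10000 nM, a limit and not a number. For the compounds shown here, no step among compound 1, compound 2 and compound 3 can therefore be read: the limit of > 10000 nM in this assay, at which 2 of the 3 values shown sit. The compounds shown leave open whether these three side chains differ at all in this assay.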